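The compounds below may be only part of what the source reports. "The series", "measured", "known", "first", "only" and "open" are said of these compounds alone.

Measured in a functional assay on A549 cells (Homo sapiens) for antiproliferative activity, read by MTT assay, with a stated time of 48 h (on this read-out lower numbers stand for stronger inhibition and higher numbers for weaker inhibition), where both values are limits of the assay:
- compound 1 `Cn1cc(-c2cnc3ccnc(NS(=O)(=O)c4ccc(C(F)(F)F)cc4)c3c2)cn1` gives > 50000 nM as a limit
- compound 2 `Cc1ccc(S(=O)(=O)Nc2nccc3ncc(-c4cnn(C)c4)cc23)cc1` gives > 50000 nM as a limit

Compound 2 stands at > 50000 nM, a limit and not a number. The evidence is the limit of > 50000 nM in this assay, at which 2 of the 2 values shown sit, and nothing more. Compound 3 `Cn1cc(-c2cnc3ccnc(NS(=O)(=O)c4cccs4)c3c2)cn1` has thiophen-2-yl in place of 4-methylphenyl on a sulfonyl sulfur. Within the data shown here, the only measured step, a step that the two limits leave unreadable from compound 1 to compound 2, gives no size to carry over. In this assay no step beyond the scatter is therefore expected, and no direction is favoured. The expected change is a number no higher from compound 2 to compound 3 (the limit leaves the size open) as estimated. The estimate for compound 3 is 50000 nM, with an expected range from 15000 nM to 100000 nM, and a further limit is likely.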

Compound 3, half-maximal inhibitory concentration: 9400 nM
Beside the measured number, compound 3's estimate is 5.3-fold (0.73 log units) above it; measured number outside the range, below it.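

Thiophen-2-yl on the sulfonyl sulfur brings the first number in this assay that is not a limit, with an at least 5.3-fold lower number from compound 2 to compound 3 (0.72 log units; beyond the scatter) and an at least 5.3-fold lower number from compound 1 to compound 3 (0.72 log units; beyond the scatter). The group on the sulfonyl sulfur can therefore move this read-out, while the step of methyl in place of trifluoromethyl cannot be read. The full size of both new steps stays open, and the comparison rests on a limit: the limit of > 50000 nM in this assay, at which 2 of the 3 values shown sit.

Going by these compounds, whether the change depends on the sulfur-containing five-membered ring or on the smaller group remains open. Furan-2-yl, pyridin-3-yl or a plain methyl on the sulfonyl sulfur could help separate these readings.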